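Trimethoxyphenyl in place of hydroxy-methoxyphenyl on the enone

This account rests on a few compounds, and the source may have more. Where it says the series, first, only, none or still open, it means among the compounds named here.

Measured so far in a functional assay on SW-620 cells (Homo sapiens) for inhibition; on this read-out higher numbers stand for weaker inhibition of growth and lower numbers for stronger inhibition of growth:
compound 1 `COc1cc(/C=C/C(=O)c2cccc(-n3cc(-c4ccc(Cl)cc4)[nH]c3=O)c2)cc(OC)c1OC`: 1750 nM
compound 2 `COc1cc(/C=C/C(=O)c2cccc(-n3cc(-c4ccccc4)[nH]c3=O)c2)cc(OC)c1OC`: 390 nM
compound 3 `COc1ccc(-c2cn(-c3cccc(C(=O)/C=C/c4ccc(O)c(OC)c4)c3)c(=O)[nH]2)cc1`: 2500 nM

Compound 3 gives the highest number of the three; compound 1 lies within the scatter of it, while compound 2 lies well below both. Going by the values given here, the only one-place step measured, a 4.5-fold lower number from compound 1 to compound 2 (0.65 log units; beyond the scatter), concerns the aryl on the shared core and does not touch the part changed here.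

Compound 4 `COc1ccc(-c2cn(-c3cccc(C(=O)/C=C/c4cc(OC)c(OC)c(OC)c4)c3)c(=O)[nH]2)cc1` differs from compound 3 by 3,4,5-trimethoxyphenyl in place of 4-hydroxy-3-methoxyphenyl on a double-bonded chain carbon bound to a double-bonded chain carbon. Among the compounds with values here, no measured pair isolates this exchange. Compounds 1 and 2 carry the group that enters, but they also differ from compound 4 at the aryl on the core, so their values only frame a range: compound 4 is expected to sit between them, nearer compound 1. The step from compound 3 is thus estimated as a 2.1-fold lower number from compound 3 to compound 4 (0.32 log units; beyond the scatter), at the edge of the scatter. For compound 4 in this assay the estimate is 1200 nM, between 400 nM and 3500 nM.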

Compound 4, concentration for 50% growth inhibition: 450 nM
For compound 4 the middle estimate is 2.7-fold (0.43 log units) above the measured one; low and high end bracket the measured number.
By their numbers in this assay, from the lowest: compounds 2 and 4 (each within the scatter of the next); then compounds 1 and 3 (each within the scatter of the next).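

In this assay 3,4,5-trimethoxyphenyl in place of 4-hydroxy-3-methoxyphenyl on a double-bonded chain carbon bound to a double-bonded chain carbon gives a 5.6-fold lower number from compound 3 to compound 4 (0.74 log units; beyond the scatter), so this position responds to the exchange when the core aryl carries methoxy. With the 3,4,5-trimethoxyphenyl group held, methoxy in place of hydrogen on an aromatic carbon gives a 1.2-fold higher number from compound 2 to compound 4 (0.06 log units; within the scatter), whereas methoxy in place of chloro gives a 3.9-fold lower number from compound 1 to compound 4 (0.59 log units; beyond the scatter), which leaves the chloro compound apart from the other two. No independent data on these compounds bear on the reason for these steps.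

The compounds shown do not separate the loss of the hydroxy group from the gain of a further methoxy group. From the compounds shown here alone, how a dimethylamino group or a carboxylic acid on this aryl would read also stays open.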